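Aryl-substituted triazole sulfonamides: methyl to fluoro swap

The source may report more compounds than this note shows. Statements on the series, on what has been measured and on what is new or still open speak of the compounds shown alone.

Three compounds of the series carry measurements in a functional assay on OVCAR-3 cells (Homo sapiens) for antiproliferative activity, read by MTT assay, with a stated time of 24 h; on this read-out lower numbers stand for stronger inhibition and higher numbers for weaker inhibition. Compound 1 `O=c1[nH]cc(S(=O)(=O)Nc2cccc(-c3cn(-c4cccc(F)c4)nn3)c2)c(=O)[nH]1` gives only a limit of this assay, > 20000 nM. Going by the values given here, compound 2 `O=c1[nH]cc(S(=O)(=O)Nc2cccc(-c3cn(-c4ccccc4Cl)nn3)c2)c(=O)[nH]1` gives 5370 nM in this assay, and the step of an at least 3.7-fold lower number from compound 1 to compound 2 (0.57 log units; beyond the scatter) is the single measured step in the set. Compound 3 `Cc1ccccc1-n1cc(-c2ccc(NS(=O)(=O)c3c[nH]c(=O)[nH]c3=O)cc2)nn1` gives 7310 nM in this assay; against compound 2 this lies within the scatter, so the two cannot be told apart. Among the compounds with values here, the remaining value is the one already noted for compound 1.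

Compound 4 `O=c1[nH]cc(S(=O)(=O)Nc2ccc(-c3cn(-c4ccccc4F)nn3)cc2)c(=O)[nH]1` differs from compound 3 by fluoro in place of methyl on an aromatic carbon. Within the data shown here, no measured step concerns this exact exchange; the step from compound 1 to compound 2 swaps one halogen for another at a different place on the same ring and is therefore only loosely related. Its size gives no basis for expecting a change beyond the scatter here.

Compound 4 is therefore expected to give about 7000 nM in this assay, within a range from 3000 nM to 20000 nM, which corresponds to an expected step of a 1.0-fold lower number from compound 3 to compound 4 (0.02 log units; within the scatter).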

Compound 4, half-maximal inhibitory concentration: 8030 nM
Compound 4: middle estimate off by 1.1-fold (0.06 log units), on the low side, within the range that was stated.
By their numbers in this assay, from the lowest: compounds 2, 3 and 4 (each within the scatter of the next). At a limit, above all of these: compound 1.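

In this assay, the exchange of 2-methylphenyl for 2-fluorophenyl, on an aromatic carbon ortho to a large group, gives a 1.1-fold higher number from compound 3 to compound 4 (0.04 log units; within the scatter), so the two cannot be told apart. For this pair, methyl and fluoro at this place are not distinguished by the read-out, though a single pair sets no rule for other groups or other cores. Going by these compounds alone, the earlier compounds could not show this, as their one step exchanged the halogen and moved it at the same time.

On these data alone, whether an amine, a carboxylic acid or a methoxy group at this place would move the number beyond the scatter stays open. Compound 1 stands as a limit and not as a number, so its distance from the other compounds cannot be read: the limit of > 20000 nM in this assay, at which 1 of the 4 values shown sits.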